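The compounds below may be only part of what the source reports. "The series", "measured", "known", "first", "only" and "open" are said of these compounds alone.

The study measures how harmful the compounds are to liver-derived cells with an ADME assay on Huh-7 cells (Homo sapiens) for cytotoxicity; on this read-out higher numbers stand for lower toxicity in this test and lower numbers for higher toxicity in this test. Going by the values given here, compound 1 `CN1CCN(CCCNCc2cn(-c3ccc([N+](=O)[O-])cc3)nc2-c2ccc(OC(F)(F)F)cc2)CC1` is the one member of the group with a numeric result: in this assay compound 1 gives 1600 nM. Compound 2 `Cc1cccc(-c2nn(-c3ccc(F)cc3F)cc2CNCCN2CCN(C)CC2)c1` reaches only the ceiling of the test: in this assay compound 2 gives > 20000 nM, which is a limit and not a number. Compound 3 `Cc1ccccc1-c1nn(-c2ccc(F)cc2F)cc1CNCCCCO` behaves the same way: in this assay compound 3 gives > 20000 nM, again a limit rather than a number. So compound 2 stands at the limit of > 20000 nM in this assay, at which 2 of the 3 values shown sit, sharing that position with compound 3, while compound 1 is the only compound with a value below it. Among the compounds with values here, no two of the measured compounds differ in just one place, so no measured step is available.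

Compound 4 `CN1CCN(CCNCc2cn(-c3ccc(F)cc3F)nc2-c2cccc(Cl)c2)CC1` differs from compound 2 by chloro in place of methyl on an aromatic carbon. Without a measured step to lean on, the expected step of a number no higher from compound 2 to compound 4 (the limit leaves the size open) is one that stays within the usual scatter of this assay, in no particular direction. Compound 4 is therefore expected to give 20000 nM in this assay, within a range from 8000 nM to 50000 nM, with a fair chance that the test again reports only its limit.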

Compound 4, half-maximal cytotoxic concentration: 15000 nM
Compound 4: the middle estimate sits 1.3-fold (0.12 log units) above what was measured; low and high end bracket the measured number.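

Going by these compounds alone, changing 3-methylphenyl to 3-chlorophenyl gives the first step that can be read in this group: in this assay it is an at least 1.3-fold lower number from compound 2 to compound 4 (0.12 log units; that floor lies within the scatter) and the floor of that step alone shows no change beyond the usual scatter. Compound 4 gives 15000 nM in this assay as an actual number, so this side of the molecule now has one measured anchor, with chloro at this place on the aromatic ring. Going by these compounds, the step can be given only as a floor, and its true size remains unknown, because compound 2 has only a limit: the limit of > 20000 nM in this assay, at which 2 of the 4 values shown sit.

One swap at one place cannot show whether other groups there, such as fluoro, methoxy or trifluoromethyl, would leave the read-out in the same region or move it clearly. The compounds shown also leave open whether the same chloro for methyl change would give a similar step on a longer chain, such as the propyl linker to the methylpiperazine, or with a nitro group on the other aromatic ring.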